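From 4-methoxyphenyl to 4-cyanophenyl in compound 4

A few compounds are considered here, and "the series" means these few. Any claim that something is new, unique, unknown or untested is made for them only; others in the source may bear on it.

In an ADME assay on L02 cells (Homo sapiens) for cytotoxicity, read by MTT assay, with a stated time of 24 h (a lower number here means a stronger inhibitor, a higher number a weaker inhibitor), compound 1 (`COc1ccc(/C=C2\CN(C)C/C(=C\c3ccccc3F)C2=O)cc1`) gives 22100 nM. Compound 3 (`CN1C/C(=C\c2cccc([N+](=O)[O-])c2)C(=O)/C(=C/c2ccccc2F)C1`) gives 13500 nM, within the scatter of compound 1, and these two share the top of the three numbers. Compound 2 (`COc1ccc(/C=C2\CN(C)C/C(=C\c3ccccc3F)C2=O)cc1OC`) gives 10500 nM.

Compound 4 (`CN1C/C(=C\c2ccc(C#N)cc2)C(=O)/C(=C/c2ccccc2F)C1`) is still unmeasured. It carries cyano in place of methoxy on an aromatic carbon, para to a large group: cyano in place of methoxy on an aromatic carbon. Among the compounds with values here, no measured compound carries cyano. Within the data shown here, the one measured step that bears on this, a 2.1-fold lower number from compound 1 to compound 2 (0.32 log units; beyond the scatter), puts in a methoxy and is modest. Compound 3, without methoxy, gives 13500 nM. A small step towards a lower number, probably within the scatter, is therefore expected: a 1.5-fold lower number from compound 1 to compound 4 (0.17 log units; within the scatter). Compound 4 is estimated at 15000 nM, with an expected range of 7500 nM to 30000 nM.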

Compound 4, half-maximal inhibitory concentration: 11000 nM
Beside the measured number, compound 4's estimate is 1.4-fold (0.13 log units) above it, and the stated range covers the measured number.
By their numbers in this assay, from the lowest: compounds 2, 4, 3 and 1 (each within the scatter of the next, the first and the last beyond it).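

In this assay, the swap of methoxy for cyano on this aromatic carbon gives a 2.0-fold lower number from compound 1 to compound 4 (0.30 log units; within the scatter), so this position accepts a nitrile in place of methoxy with no change beyond the scatter. The methoxy of compound 1 is therefore not needed to keep the number in this range. Nothing available explains this result.

From the compounds shown here alone, whether an amine or a carboxylic acid on the same aromatic carbon would also stay within the scatter of compound 1 remains open. So does the effect of a longer chain, such as ethoxy, there.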